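The source may report more compounds than this note shows. Statements on the series, on what has been measured and on what is new or still open speak of the compounds shown alone.

Working notes on a short series of bromoacrylamide-substituted chalcones tested in a functional assay on FM3A cells (Mus musculus) for antiproliferative activity, with a stated time of 48 h; a lower number here means a stronger inhibitor, a higher number a weaker inhibitor.

Compound 1 `C=C(Br)C(=O)Nc1ccc(C(=O)/C=C/c2ccccc2)cc1` is the unsubstituted parent; in this assay compound 1 gives 690 nM. Compound 2 `C=C(Br)C(=O)Nc1ccc(C(=O)/C=C/c2cccc(OC)c2)cc1` carries a methoxy in place of hydrogen on an aromatic carbon, and in this assay compound 2 gives 1800 nM. That single change produced a 2.6-fold higher number from compound 1 to compound 2 (0.42 log units; beyond the scatter). Compound 3 `C=C(Br)C(=O)Nc1ccc(C(=O)/C=C/c2ccc(OC)cc2OC)cc1` carries two methoxy groups on the same ring; in this assay compound 3 gives 1200 nM, which lies within the scatter of compound 2 and also within the scatter of compound 1. The difference between the core of compound 1 and the core of compound 3 is not broken down here.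

Compound 4 `C=C(Br)C(=O)Nc1ccc(C(=O)/C=C/c2ccc(OC)c(OC)c2OC)cc1` has not yet been measured. It differs from compound 3 by a methoxy in place of hydrogen on an aromatic carbon, on an aromatic carbon that is ortho to two methoxy groups and meta to a large group, whereas the change from compound 1 to compound 2 was placed only meta to a large group. It is therefore the same kind of change, not the same change. Among the measured compounds shown here, the one measured instance, from compound 1 to compound 2, gave a modest loss, and the step from compound 2 to compound 3 stayed within the scatter, so a step of similar or smaller size is expected for compound 4, a 1.3-fold higher number from compound 3 to compound 4 (0.12 log units; within the scatter), because the only measured precedent is a 2.6-fold higher number from compound 1 to compound 2 (0.42 log units; beyond the scatter). Compound 4 is accordingly expected to give an estimated 1600 nM in this assay, with a range of 600 nM to 4500 nM.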

Compound 4, half-maximal inhibitory concentration: 530 nM
Beside the measured number, compound 4's estimate is 3.0-fold (0.48 log units) above it; the whole stated range lies above it.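

In this assay the new step is a 2.3-fold lower number from compound 3 to compound 4 (0.35 log units; beyond the scatter), so the methoxy in place of hydrogen on an aromatic carbon runs in the opposite direction to its earlier instance, and the two instances differ: the same change on two cores in this assay, a 2.6-fold higher number (0.42 log units; beyond the scatter) from compound 1 to compound 2 and a 2.3-fold lower number (0.35 log units; beyond the scatter) from compound 3 to compound 4, 5.9-fold (0.77 log units) apart, beyond the scatter of two such steps

For this series, the change therefore cannot be carried from one core to another as a fixed step, and the direction seen on one core does not set the direction on the next. The comparison does not show what separates the two instances: the core differs and so does the place, the new methoxy in compound 4 being ortho to two methoxy groups and meta to a large group, and two pairs cannot divide the difference between these factors.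

Open, from the compounds shown here alone, is whether the lower number at this place depends on the two methoxy groups already present in compound 3, or would also appear with the same methoxy on a different core. Also open, going by these compounds, is whether a hydroxyl, an amine, a fluorine atom or a longer chain such as ethoxy at this place would follow the direction of the methoxy.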